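A few compounds are considered here, and "the series" means these few. Any claim that something is new, unique, unknown or untested is made for them only; others in the source may bear on it.

Working notes on the series. Of the compounds shown here, three carry numbers so far in a functional assay on MCF7 cells (Homo sapiens) for inhibition, read by MTT assay, with a stated time of 72 h; a higher number here means a weaker inhibitor, a lower number a stronger inhibitor. Compound 1 `Cc1cc(Nc2ccn(Cc3cccc4ccccc34)n2)n2nc(SCc3ccc(Br)cc3)nc2n1` gives 4310 nM in this assay. Compound 2 `Cc1cc(Nc2cc(-c3ccccc3)[nH]n2)n2nc(SCc3csc4ccccc34)nc2n1` gives 3470 nM in this assay. Compound 3 `Cc1cc(Nc2cc(-c3cccs3)[nH]n2)n2nc(SCc3ccc(Br)cc3)nc2n1` gives 5370 nM in this assay. Compound 2 shows the lowest of the three numbers, but its gap to compound 1 and its gap to compound 3 both lie within the scatter, so the three are not separated by this assay.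

The next compound, compound 4 `CCCSc1nc2nc(C)cc(Nc3cc(-c4ccccc4)[nH]n3)n2n1`, is not yet measured in this assay. Its change from compound 2 is ethyl in place of 1-benzothiophen-3-yl on a saturated chain carbon bound to a sulfur. Within the data shown here, no pair of measured compounds differs in one place, so no measured step guides this change; the three measured compounds all carry a ring-bearing group on the sulfur, and none shows the effect of cutting that group to a short chain. The loss of the 1-benthiophen-3-yl group, nine heavy atoms with two aromatic rings, against a two-carbon ethyl, is expected to move the number upward by a step of a 3.5-fold higher number from compound 2 to compound 4 (0.54 log units; beyond the scatter), beyond the scatter. Compound 4 is therefore estimated at 12000 nM in this assay, within a range from 3500 nM to 40000 nM.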

Compound 4, half-maximal inhibitory concentration: > 50000 nM
Compound 4: no number, only a limit (the forecaster's own chance of this, stated with the estimate: 25%); middle value at least 4.1-fold (0.61 log units) from the limit.
By their numbers in this assay, from the lowest: compounds 2, 1 and 3 (each within the scatter of the next). At a limit, above all of these: compound 4.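

In this assay compound 4 gives > 50000 nM, which is a limit of the assay and not a number: the limit of > 50000 nM in this assay, at which 1 of the 4 values shown sits. Ethyl in place of 1-benzothiophen-3-yl on a saturated chain carbon bound to a sulfur gives an at least 14-fold higher number from compound 2 to compound 4 (1.15 log units; beyond the scatter), the first step in the series that lies beyond the scatter. This position therefore separates compounds where the earlier three did not, and with the rest of compound 2 kept, the ring-bearing group on the sulfur cannot be cut to the propylsulfanyl chain of compound 4 without a large rise in the number.

As far as these compounds go, this rests on a single pair, so it remains open whether the rings themselves or only the size of the group count. A cyclohexylmethyl group or a longer chain such as octyl on the sulfur would separate the two.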